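Cyclohexyl for 4-methylphenyl on the amide nitrogen

This account rests on a few compounds, and the source may have more. Where it says the series, first, only, none or still open, it means among the compounds named here.

Compound 1 `CCOC(=O)C1=Cc2ccccc2OC1(OCc1cn(CC(=O)Nc2ccc(C)cc2)nn1)C(F)(F)F` was tested in a functional assay on MCF7 cells (Homo sapiens) for inhibition, read by MTT assay, with a stated time of 24 h; on this read-out lower numbers stand for stronger inhibition and higher numbers for weaker inhibition. In this assay compound 1 gives only a limit of the assay, > 150000 nM. Compound 2 `CCOC(=O)C1=Cc2ccccc2OC1(OCc1cc(-c2ccc(Br)cc2)no1)C(F)(F)F` likewise gives only a limit, > 150000 nM. Compound 3 `COc1ccc(-c2cc(COC3(C(F)(F)F)Oc4ccccc4C=C3C(=O)O)on2)cc1` gives 35200 nM in this assay. Going by the values given here, compound 1 therefore sits at the limit of > 150000 nM in this assay, at which 2 of the 3 values shown sit, and no step from it to another measured compound is available. Compound 4 `CCOC(=O)C1=Cc2ccccc2OC1(OCc1cn(CC(=O)NC2CCCCC2)nn1)C(F)(F)F` differs from compound 1 by cyclohexyl in place of 4-methylphenyl on an amide-type nitrogen. Among the compounds with values here, no measured pair shows the effect of such a change, so the expected step is no larger than the scatter, in either direction, namely a number no higher from compound 1 to compound 4 (the limit leaves the size open). Compound 4 is estimated at 150000 nM, within 50000 nM to 500000 nM, and is most likely again reported only as a limit.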

Compound 4, half-maximal inhibitory concentration: 12100 nM
Beside the measured number, compound 4's estimate is 12-fold (1.09 log units) above it, outside the stated range (below it).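

In this assay, the substituent on the amide-type nitrogen proves able to move the read-out: cyclohexyl in place of 4-methylphenyl gives an at least 12-fold lower number from compound 1 to compound 4 (1.09 log units; beyond the scatter). Going by these compounds alone, this is the first step between measured compounds, and it replaces an aromatic six-membered ring of carbon with a non-aromatic one. Going by these compounds, its full size stays open, since compound 1 gives only a limit: the limit of > 150000 nM in this assay, at which 2 of the 4 values shown sit.

On these data alone, whether the change in ring type or the loss of the methyl carries the step remains open. Also open, as far as these compounds go, is how a plain phenyl, an open-chain hexyl or an aminocyclohexyl on that nitrogen would read.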